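The compounds below may be only part of what the source reports. "The series", "measured", "known", "first", "only" and "open" are said of these compounds alone.

Compound 1 `Nc1ccccc1NC(=O)c1ccc(CSC(=S)N2CCN(Cc3ccccn3)CC2)cc1` and compound 2 `Nc1ccccc1NC(=O)c1ccc(CSC(=S)N2CCN(c3ccc(Cl)cc3)CC2)cc1` share a core and differ only in the group on the amine nitrogen in the ring. In a functional assay on MGC-803 cells (Homo sapiens) for antiproliferative activity, read by CCK-8 assay, with a stated time of 72 h, tested at 2 uM (on this read-out lower numbers stand for a weaker effect and higher numbers for a stronger effect at the one concentration tested), compound 1 gives 23.4%, the highest of the two numbers recorded, and compound 2 gives 15%; the step of a number 8.4 percentage points lower from compound 1 to compound 2 (within the scatter) stays within the scatter, so the two compounds cannot be set in order.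

Compound 3 `COc1ccc(N2CCN(C(=S)SCc3ccc(C(=O)Nc4ccccc4N)cc3)CC2)cc1` has not yet been measured. It arises from compound 1 by the change (4-methoxyphenyl in place of (pyridin-2-yl)methyl on an amine nitrogen in a ring). Going by the values given here, the one measured step that bears on this change is the one from compound 1 to compound 2, in which an aromatic group likewise took the place of (pyridin-2-yl)methyl on that ring nitrogen and moved the read-out by a number 8.4 percentage points lower from compound 1 to compound 2 (within the scatter), within the scatter. On that basis the step of a number 6.4 percentage points lower from compound 1 to compound 3 (within the scatter) is expected to be small, if anything a little downward, and not beyond the scatter. Compound 3 is therefore estimated to give 17% in this assay, within a range from 5% to 30%.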

Compound 3, a percentage reported as inhibition, at one concentration (the size of the read-out at that concentration, not a potency): 25.3%
Compound 3: middle estimate off by 8.3 percentage points, on the low side; low and high end bracket the measured number.
By their numbers in this assay, from the lowest: compounds 2, 1 and 3 (each within the scatter of the next, the first and the last beyond it).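

In this assay, 4-methoxyphenyl in place of (pyridin-2-yl)methyl on the amine nitrogen in the ring gives a step (a number 1.9 percentage points higher from compound 1 to compound 3 (within the scatter)) that stays within the scatter, so compound 1 and compound 3 cannot be set in order, and a carbon-only aromatic ring on that nitrogen does not in itself go with a loss of read-out. Going by these compounds alone, the new information lies in the other step, methoxy in place of chloro on an aromatic carbon (a number 10.3 percentage points higher from compound 2 to compound 3 (beyond the scatter)), which is modest but is the first step in this set to pass beyond the scatter, showing that the read-out at this position can respond to the group carried on that aromatic ring. The data offer no evidence on why methoxy and chloro differ here.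

A single pair cannot show whether this difference extends to other groups on that aromatic carbon, such as a hydroxy group, a dimethylamino group or a plain hydrogen in an unsubstituted phenyl. As far as these compounds go, all three numbers also come from one concentration, so how the compounds compare in potency remains open.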